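A Nitrile-Bearing Ring Replaces the Fluorophenyl in Compound 4

The source may hold more compounds than are shown below. What is called first, only, known or untested is meant among the compounds shown, and "the series" means these compounds.

Compound 1 `CC1=C(/C=C/C(=O)/C=C/c2ccccc2F)C(C)(C)CCC1O` gives the highest of the three measured numbers: in a functional assay on LNCaP cells (Homo sapiens) for cytotoxicity, read by MTT assay, with a stated time of 72 h (a lower number here means a stronger inhibitor, a higher number a weaker inhibitor), compound 1 gives 2900 nM. Compound 2 `CC1=C(/C=C/C(=O)/C=C/c2cccc(C(F)(F)F)c2F)C(C)(C)CCC1O` gives 1100 nM, and compound 3 `CC1=C(/C=C/C(=O)/C=C/c2ccc(C(F)(F)F)cc2F)C(C)(C)CCC1O` gives 2600 nM. The change to compound 4 `CC1=C(/C=C/C(=O)/C=C/c2cccc(C#N)c2)C(C)(C)CCC1O` is 3-cyanophenyl in place of 2-fluorophenyl on a double-bonded chain carbon bound to a double-bonded chain carbon. The measured steps touch the same aromatic ring: a 2.6-fold lower number from compound 1 to compound 2 (0.42 log units; beyond the scatter) and a 1.1-fold lower number from compound 1 to compound 3 (0.05 log units; within the scatter). Both keep the fluorine and add a trifluoromethyl, whereas compound 4 loses the fluorine and gains a nitrile, so neither step matches it closely. Those steps suggest that changes on this ring shift this assay only modestly, so the step expected is a 1.5-fold lower number from compound 1 to compound 4 (0.16 log units; within the scatter). Compound 4 is therefore estimated at 2000 nM, with a range from 700 nM to 6000 nM.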

Compound 4, half-maximal inhibitory concentration: 1800 nM
For compound 4 the middle estimate is 1.1-fold (0.05 log units) above the measured one, and the stated range covers the measured number.
By their numbers in this assay, from the lowest: compounds 2, 4, 3 and 1 (each within the scatter of the next, the first and the last beyond it).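

In this assay, 3-cyanophenyl in place of 2-fluorophenyl gives a 1.6-fold lower number from compound 1 to compound 4 (0.21 log units; within the scatter) and so leaves the number within the scatter. The earlier steps shown here all kept the fluorine, whereas this one shows that the ring can lose it and carry a nitrile instead with no clear change in this assay. No measurement shown explains this result.

The swap removes the fluorine and adds the nitrile at once, and the compounds shown do not separate those two changes. From the compounds shown here alone, how an amine or a carboxylic acid on this ring would read also stays open.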